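Acylhydrazone series: removing the chloro group

This account rests on a few compounds, and the source may have more. Where it says the series, first, only, none or still open, it means among the compounds named here.

Measured so far in a functional assay on HT-29 cells (Homo sapiens) for antiproliferative activity, read by sulforhodamine B assay, with a stated time of 48 h; on this read-out higher numbers stand for weaker inhibition of growth and lower numbers for stronger inhibition of growth: compound 1 `COc1ccc(OC)c(/C=C/c2nnc(Nc3ccc(Cl)cc3)o2)c1` gives 9440 nM; compound 2 `COc1ccc(OC)c(/C=C/C(=O)N/N=C/c2ccc(Cl)cc2)c1` gives 43.5 nM.

Compound 2 stands lowest of the two numbers in this assay; compound 1 sits far higher, beyond the scatter. The next step goes from compound 2 to compound 3 `COc1ccc(OC)c(/C=C/C(=O)N/N=C/c2ccccc2)c1`: hydrogen in place of chloro on an aromatic carbon. Among the measured compounds shown here, no measured pair shows this change, so no step size is known from the data. Because compound 2 gives 43.5 nM, the loss of a single halogen is expected to cost little, at most a modest rise within or just beyond the scatter. The step of a 2.3-fold higher number from compound 2 to compound 3 (0.36 log units; beyond the scatter) is the expected outcome. Compound 3 is estimated at 100 nM, range 25 nM to 400 nM.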

Compound 3, concentration for 50% growth inhibition: 2100 nM
For compound 3 the middle estimate is 21-fold (1.32 log units) below the measured one; measured number above the stated range.
By their numbers in this assay, from the lowest: compound 2; then compound 3; then compound 1.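

In this assay the change from 4-chlorophenyl to phenyl gives a 48-fold higher number from compound 2 to compound 3 (1.68 log units; beyond the scatter), so a single chlorine on this aromatic carbon, para to a large group, separates a potent acylhydrazone from a much weaker one. This position is therefore highly sensitive to this change, at least for this pair. Nothing shown accounts for the size of this step.

From the compounds shown here alone, whether bromo, an amine or a carboxylic acid at this place would restore the number of compound 2 remains open. So does whether the same change matters as much on the core of compound 1.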